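The source may hold more compounds than are shown below. What is called first, only, known or untested is meant among the compounds shown, and "the series" means these compounds.

Compound 1, `N#Cc1ccc(C(c2ccc(C#N)cc2)n2cc(COc3ccccc3)nn2)cc1`, gives 11000 nM in an assay on isolated protein for inhibition of Aromatase (Homo sapiens), read by fluorescence and colorimetric assay, with a stated time of 30 min; on this read-out higher numbers stand for weaker inhibition and lower numbers for stronger inhibition.
Compound 2, `c1ccc(C(c2ccccc2)n2ccnn2)cc1`, gives 4580 nM in this assay.

Of the compounds shown here, two have been measured so far. Compound 2, the plain core without any substituent on its five-membered ring, stands lower than compound 1 in this assay, and the gap between the two numbers lies beyond the usual scatter, so compound 2 is the stronger inhibitor of the pair. Compound 1 carries nitrile groups on both benzene rings as well as a phenoxymethyl group on the five-membered ring, so its weaker number cannot be traced to any single change.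

Compound 3, `c1ccc(C(c2ccccc2)n2cc(C3CCCCC3)nn2)cc1`, has not yet been measured. It differs from compound 2 in one place: cyclohexyl in place of hydrogen on an aromatic carbon. Among the measured compounds shown here, no measured pair shows the effect of such a change, so the direction of the step cannot be read from the numbers at hand. A modest step is expected, most likely toward a somewhat lower number, as a 1.3-fold lower number from compound 2 to compound 3 (0.12 log units; within the scatter), but a result within the scatter would not surprise. Compound 3 is therefore estimated at 3500 nM, with a plausible range from 800 nM to 15000 nM.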

Compound 3, half-maximal inhibitory concentration: 13700 nM
For compound 3 the middle estimate is 3.9-fold (0.59 log units) below the measured one; the range from low to high includes it.
By their numbers in this assay, from the lowest: compound 2; then compounds 1 and 3 (each within the scatter of the next).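

Among the compounds shown here, compound 2 and compound 3 form the first pair that isolates this position. In this assay, cyclohexyl in place of hydrogen on an aromatic carbon of the five-membered ring gives a step toward weaker inhibition (a 3.0-fold higher number from compound 2 to compound 3 (0.48 log units; beyond the scatter)). The earlier pair differed in several places and could not show that one change at this carbon, with no hydrogen-bond donors or acceptors in the entering group, is enough to move the number beyond the scatter on the plain core. Nothing at hand gives a measured reason for this result.

For the compounds shown here, the single pair leaves open whether the higher number belongs to cyclohexyl in particular or would follow from other groups on this carbon, such as methyl, phenyl, an amine or a carboxylic acid. It also leaves open what the nitrile groups on the benzene rings and the phenoxymethyl group each contribute on their own, since the compounds shown do not separate these two changes from each other.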